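Moving a Hydroxyl Group on a Shared Core

This account rests on a few compounds, and the source may have more. Where it says the series, first, only, none or still open, it means among the compounds named here.

Of the compounds shown here, three have so far been measured in an assay on isolated protein for inhibition of DNA topoisomerase 1 (Homo sapiens), with a stated time of 30 min, tested at 100 uM; a higher number here means a stronger effect of the compound at the concentration tested, a lower number a weaker effect. Compound 1 `Oc1cccc(-c2cc(-c3ccco3)cc(-c3ccccc3O)n2)c1` gives 90.1% in this assay. Compound 2 `Oc1ccc(-c2cc(-c3ccco3)cc(-c3ccccc3O)n2)cc1` differs from compound 1 in one place, namely (4-hydroxyphenyl in place of 3-hydroxyphenyl on an aromatic carbon), and in this assay compound 2 gives 83%; the resulting step is a number 7.1 percentage points lower from compound 1 to compound 2 (within the scatter). Compound 3 `Oc1cccc(-c2cc(-c3ccccn3)cc(-c3cccc(O)c3)n2)c1` carries a different core, and how that core differs from the core of compound 1 is not broken down here. In this assay compound 3 gives 8.3%, the lowest of the three values and beyond the scatter from both compound 1 and compound 2.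

Compound 4 `Oc1ccc(-c2cc(-c3ccccn3)cc(-c3cccc(O)c3)n2)cc1` has not yet been measured. It differs from compound 3 by 4-hydroxyphenyl in place of 3-hydroxyphenyl on an aromatic carbon. Going by the values given here, this is the same kind of change as the one separating compound 1 from compound 2, though the surroundings are not identical: in compound 3 the place is meta to a 3-hydroxyphenyl group and meta to a pyridin-2-yl group, whereas in compound 1 it is meta to a 2-hydroxyphenyl group and meta to a furan-2-yl group. The expected step is a number 3.3 percentage points lower from compound 3 to compound 4 (within the scatter), which rests on the earlier step being a number 7.1 percentage points lower from compound 1 to compound 2 (within the scatter) and on the small starting value of compound 3 at 8.3%, leaving little room for a further fall. Compound 4 is therefore estimated to give 5% in this assay, with a likely range from -5% to 20%.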

Compound 4, a percentage reported as inhibition, at one concentration (the size of the read-out at that concentration, not a potency): 2.4%
For compound 4 the middle estimate is 2.6 percentage points above the measured one, and the stated range covers the measured number.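

In this assay, the exchange of 3-hydroxyphenyl for 4-hydroxyphenyl on the core of compound 3 gives a step that can be read directly, a number 5.9 percentage points lower from compound 3 to compound 4 (within the scatter), and it matches the earlier step on the core of compound 1: the same change on two cores in this assay, a number 7.1 percentage points lower (within the scatter) from compound 1 to compound 2 and a number 5.9 percentage points lower (within the scatter) from compound 3 to compound 4, 1.2 percentage points apart, within the scatter of two such steps Across these two pairs, then, the exchange carries from one core to the other without a step beyond the scatter, so in this small set the effect of moving the hydroxyl group looks independent of the core. Going by these compounds alone, this does not show that the exchange is without effect on every core, and it rests on only two pairs, each read at a single concentration, so it gives no potency, and compound 3 already starts from a small read-out of 8.3%.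

The compounds shown leave open what separates the two cores, since a furan-2-yl group and a 2-hydroxyphenyl group in compound 1 stand where compound 3 has a pyridin-2-yl group and a 3-hydroxyphenyl group, and neither exchange is seen alone. They also leave open whether a methoxy group, an amine or a carboxylic acid in place of the hydroxyl group would behave in the same way.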